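A few compounds are considered here, and "the series" means these few. Any claim that something is new, unique, unknown or untested is made for them only; others in the source may bear on it.

Measured compounds:
compound 1, `COc1cc(C2=NN(C(C)=O)C(c3c(Cl)cccc3Cl)O2)cc(OC)c1OC`: -1.4%
compound 2, `COc1ccc(OC)c(C2OC(c3cc(OC)c(OC)c(OC)c3)=NN2C(C)=O)c1`: 0.4%

In a functional assay on BGC-823 cells (Homo sapiens) for antiproliferative activity, read by MTT assay, tested at 1 uM (on this read-out higher numbers stand for a stronger effect at the one concentration tested and lower numbers for a weaker effect), compound 2 holds the higher of the two numbers, yet the step of a number 1.8 percentage points higher from compound 1 to compound 2 (within the scatter) is within the scatter, so the two compounds cannot be told apart. Compound 3, `COc1cc(C2=NN(C(C)=O)C(c3ccc(F)cc3)O2)cc(OC)c1OC`, differs from compound 2 at the same saturated ring carbon: 4-fluorophenyl in place of 2,5-dimethoxyphenyl on a saturated ring carbon. Among the measured compounds shown here, the only step that bears on this change is a number 1.8 percentage points higher from compound 1 to compound 2 (within the scatter), in which another aryl group at that carbon gave no shift beyond the scatter. Compound 3 is therefore expected to show no step beyond the scatter, a number 0.6 percentage points higher from compound 2 to compound 3 (within the scatter). Compound 3 is estimated at 1%, in the range -9% to 11%.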

Compound 3, a percentage reported as inhibition, at one concentration (the size of the read-out at that concentration, not a potency): -0.4%
For compound 3 the middle estimate is 1.4 percentage points above the measured one; the range from low to high includes it.
By their numbers in this assay, from the lowest: compounds 1, 3 and 2 (each within the scatter of the next).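

In this assay the 4-fluorophenyl group on the saturated ring carbon gives a number 0.8 percentage points lower from compound 2 to compound 3 (within the scatter) and a number 1 percentage points higher from compound 1 to compound 3 (within the scatter) in the two comparisons. A third aryl group, carrying fluorine in place of the chlorines or methoxy groups, therefore still does not separate the compounds at this position, and all three remain indistinguishable at the one concentration tested. No evidence is available to explain this result. Still open, from the compounds shown here alone, is whether a carboxylic acid, an amine or a longer alkyl chain at this carbon would move the number beyond the scatter.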